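This account rests on a few compounds, and the source may have more. Where it says the series, first, only, none or still open, it means among the compounds named here.

Of the compounds shown here, three have been read so far in a functional assay on NCI-H1975 cells (Homo sapiens) for antiproliferative activity, read by MTT assay, with a stated time of 72 h (a higher number here means a weaker inhibitor, a lower number a stronger inhibitor), and only two of them give a number. Compound 1 `O=C(O)CCC(=O)Nc1cc(Nc2ccc(Cl)cc2)ncn1` gives 2730 nM and compound 3 `O=C(O)CCCC(=O)Nc1cc(Nc2ccccc2)ncn1` gives 1850 nM, two values that lie within the scatter of each other. Compound 2 `COc1ccc(OC)c(Nc2cc(Nc3ccc(F)cc3)ncn2)c1` reads > 30000 nM, which is a limit of the assay and not a number. Within the data shown here, compound 2 therefore has no measured potency to start from, and no step between measured compounds that differ in one place is available as a guide.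

Compound 4 `COc1ccc(OC)c(Nc2cc(Nc3ccc(N4CCN(C)CC4)cc3)ncn2)c1` keeps the rest of compound 2 and changes one group: 4-methylpiperazin-1-yl in place of fluoro on an aromatic carbon. The 4-methylpiperazin-1-yl group takes the place of fluoro on an aromatic carbon, para to a large group. The expectation of a gain rests only on the range of numbers seen so far, with compound 1 at 2730 nM and compound 3 at 1850 nM. The expected change in this assay is a move toward stronger inhibition, estimated as an at least 5.0-fold lower number from compound 2 to compound 4 (0.69 log units; beyond the scatter), although a reading that stays at the limit remains possible. Compound 4 is expected to give about 6000 nM, with an estimated range from 1000 nM to 30000 nM.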

Compound 4, half-maximal inhibitory concentration: > 30000 nM
Compound 4: only a limit was reported; the forecaster's own chance of this, stated with the estimate: 25%; middle value at least 5.0-fold (0.69 log units) from the limit.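

In this assay compound 4 gives > 30000 nM, which is a limit of the assay and not a number. Compound 2 and compound 4 both stand at a limit, so no step between them can be read: the limit of > 30000 nM in this assay, at which 2 of the 4 values shown sit.

The compounds shown leave open whether 4-methylpiperazin-1-yl in place of fluoro changes potency at all.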